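Compound 1 to its propyl ester: an antiproliferative estimate

A few compounds are considered here, and "the series" means these few. Any claim that something is new, unique, unknown or untested is made for them only; others in the source may bear on it.

Compound 1 `C/C=C1/[C@H](O[C@@H]2O[C@H](COC(C)=O)[C@@H](OC(C)=O)[C@H](OC(C)=O)[C@H]2OC(C)=O)OC=C(C(=O)OC)[C@H]1CC(=O)O`: > 15000 nM
Compound 2 `C/C=C1/[C@H](O[C@@H]2O[C@H](CO)[C@@H](O)[C@H](O)[C@H]2O)OC=C(C(=O)OC)[C@H]1CC(=O)OCCc1ccc(F)cc1`: > 20000 nM

Both compounds were tested in a functional assay on SK-BR-3 cells (Homo sapiens) for antiproliferative activity, read by MTT assay, with a stated time of 72 h (on this read-out lower numbers stand for stronger inhibition and higher numbers for weaker inhibition), and neither yields a number. Compound 1 stands at > 15000 nM, which is a limit of the assay, so its true position is not known. Compound 2 reads > 20000 nM, which is likewise a limit. Together the two results show only that no half-maximal inhibitory concentration was reached for either compound, and they cannot be placed in order.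

Compound 3 `C/C=C1/[C@H](O[C@@H]2O[C@H](COC(C)=O)[C@@H](OC(C)=O)[C@H](OC(C)=O)[C@H]2OC(C)=O)OC=C(C(=O)OC)[C@H]1CC(=O)OCCC` has not yet been measured. It departs from compound 1 by propyl in place of hydrogen on an oxygen next to a carbonyl group, with propyl in place of hydrogen on an oxygen next to a carbonyl group, so that carboxymethyl becomes (propoxycarbonyl)methyl. Going by the values given here, no measured step in this assay shows what this change does, so any expectation remains rough. A small move toward stronger inhibition is expected, and it may not clear the usual scatter. The expected step is an at least 1.2-fold lower number from compound 1 to compound 3 (0.09 log units; that floor lies within the scatter). Compound 3 is estimated at 12000 nM, with an expected range from 4000 nM to 40000 nM.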

Compound 3, half-maximal inhibitory concentration: 6600 nM
Beside the measured number, compound 3's estimate is 1.8-fold (0.26 log units) above it, and the stated range covers the measured number.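

Compound 3 gives the first measured half-maximal inhibitory concentration among the compounds shown in this assay, where the earlier results offered only limits. The change from carboxymethyl to (propoxycarbonyl)methyl, with propyl in place of hydrogen on an oxygen next to a carbonyl group, gives an at least 2.2-fold lower number from compound 1 to compound 3 (0.35 log units; beyond the scatter) and so shows that this position responds in this assay, something that the two limits alone could not show. As far as these compounds go, the true size of the step remains unknown, and the figure stands only as a minimum, because compound 1 sits at a limit of the assay: the limit of > 15000 nM in this assay, at which 1 of the 3 values shown sits.

From the compounds shown here alone, whether a methyl group, a longer chain or an amide in place of the propyl ester would move the number further remains open, so no trend with chain length can be drawn from this single step. Going by these compounds, the part played by the acetyl groups that compound 3 carries also stays open, for compound 2 differs from compound 3 in more than one place and the two cannot be compared.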